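The source may hold more compounds than are shown below. What is called first, only, known or untested is meant among the compounds shown, and "the series" means these compounds.

Measured compounds:
Compound 1 `Cc1nc(NC(=O)c2ccccc2)c2nn(-c3ccccc3)cc2n1` gives 5.6 nM in an assay on CHO cells for displacement of a labelled ligand from adenosine receptor A3 (Homo sapiens), read by scintillation counting, with a stated time of 60 min; a higher number here means a weaker inhibitor, a lower number a stronger inhibitor.
Compound 2 `COc1ccc(-n2cc3nc(-c4ccccc4)nc(N)c3n2)cc1` gives 75 nM in this assay.

Among the measured compounds shown here, only two compounds have been measured, and compound 2 has the higher of the two numbers; compound 1 gives a number that is lower by a margin beyond the usual scatter, so compound 1 is the stronger inhibitor of the pair. The two structures differ in several places at once, so no single structural change can be tied to that gap.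

Compound 3 `COc1ccc(-n2cc3nc(-c4ccccc4)nc(NC(C)=O)c3n2)cc1` has not yet been measured. It is built from compound 2 by one change: acetyl in place of hydrogen on a nitrogen on an aromatic ring. Compound 1 also carries an acyl group on that same kind of nitrogen and gives the lower number, which is the only hint available here. On that basis compound 3 is expected to give a lower number than compound 2, by a step of about a 5.0-fold lower number from compound 2 to compound 3 (0.70 log units; beyond the scatter) in this assay. The estimated value for compound 3 is 15 nM, with a likely range from 3 nM to 60 nM.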

Compound 3, inhibition constant: 98 nM
Estimate against measurement, compound 3: 6.5-fold (0.82 log units) below; the whole stated range lies below it.
By their numbers in this assay, from the lowest: compound 1; then compounds 2 and 3 (each within the scatter of the next).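

Among the compounds shown here, replacing hydrogen with acetyl on a nitrogen on an aromatic ring in this assay gives a 1.3-fold higher number from compound 2 to compound 3 (0.12 log units; within the scatter) and so offers the first reading of this position on its own. On this core, amino and acetamido cannot be told apart in this measurement, and the nitrogen accepts the added acetyl with no change beyond the usual scatter. An acetyl group on this nitrogen is therefore not enough by itself to account for the number of compound 1, which differs from compound 3 in several places, and nothing here explains why this change leaves the number within the scatter.

Still open, on these data alone, is whether a different group on this nitrogen, such as a longer acyl chain like butanoyl, a methyl group or a methanesulfonyl group, would move the number beyond the scatter. As far as these compounds go, it is also open whether amino and acetamido would read alike on the core of compound 1, or whether the outcome of this change depends on the other places where compound 1 and compound 3 differ.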